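Swapping Methoxy for Methyl in a Cytotoxicity Assay

The source may report more compounds than this note shows. Statements on the series, on what has been measured and on what is new or still open speak of the compounds shown alone.

Compound 2 `COc1ccc(/C=N/NC(=O)CSc2nnnn2C)cc1` was tested in an ADME assay on NIH3T3 cells (Mus musculus) for cytotoxicity, read by XTT assay, with a stated time of 24 h; on this read-out lower numbers stand for stronger inhibition and higher numbers for weaker inhibition. In this assay compound 2 gives > 10000000 nM, which is a limit of the assay rather than a number; this is the limit of > 10000000 nM in this assay, at which 1 of the 3 values shown sits. Compound 1 `Cc1ccc(/C=N/NC(=O)CSc2nnnn2C)cc1` differs from it by methyl in place of methoxy on an aromatic carbon, and in this assay compound 1 gives 3160000 nM. That change made a step of an at least 3.1-fold lower number from compound 2 to compound 1 (0.50 log units; beyond the scatter). Compound 3 `COc1ccccc1/C=N/NC(=O)CSc1nnnn1C` has the same atoms as compound 2 joined differently; the difference between the two cores is not broken down here. In this assay compound 3 gives 3160000 nM. Compound 4 `Cc1ccccc1/C=N/NC(=O)CSc1nnnn1C` carries the same kind of change, (methyl in place of methoxy on an aromatic carbon), here ortho to a large group rather than para to it. Because the step of an at least 3.1-fold lower number from compound 2 to compound 1 (0.50 log units; beyond the scatter) lowered the number, compound 4 is expected to show a step of a 1.6-fold lower number from compound 3 to compound 4 (0.20 log units; within the scatter). Compound 4 is estimated to give 2000000 nM.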

Compound 4, half-maximal inhibitory concentration: 6320000 nM
Beside the measured number, compound 4's estimate is 3.2-fold (0.50 log units) below it; the measured number lies above the stated range.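

In this assay, methyl in place of methoxy gave a 2.0-fold higher number from compound 3 to compound 4 (0.30 log units; within the scatter), so the clear drop seen with the same swap on the other core did not repeat here. The change therefore does not carry over as one fixed step between these two cores: the same change on two cores in this assay, an at least 3.1-fold lower number (0.50 log units; beyond the scatter) from compound 2 to compound 1 and a 2.0-fold higher number (0.30 log units; within the scatter) from compound 3 to compound 4, at least 6.3-fold (0.80 log units) apart, beyond the scatter of two such steps. This does not show a real rise on the core of compound 3, as the new step lies within the scatter, and the earlier step starts from a value that is a limit of the assay and not a number: the limit of > 10000000 nM in this assay, at which 1 of the 4 values shown sits.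

The compounds shown leave open whether the mismatch follows the place of the group, ortho to a large group in compound 4, or some other feature of the core. They also leave open how a different group at that place, such as an amine or a carboxylic acid, would behave.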